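From furan-3-yl to ethynyl on a shared core

The source may report more compounds than this note shows. Statements on the series, on what has been measured and on what is new or still open speak of the compounds shown alone.

In a functional assay on CEM-DNR-bulk cells (Homo sapiens), read by MTT assay, with a stated time of 72 h (a higher number here means a weaker inhibitor, a lower number a stronger inhibitor), compound 2 `Cc1ncnc2c1c(-c1ccoc1)cn2[C@@H]1O[C@H](CO)[C@@H](O)[C@H]1O` reads > 20000 nM, which is a limit of the assay and not a number. Going by the values given here, that leaves compound 2 at the weak end of the two values so far. Compound 3 `C#Cc1cn([C@@H]2O[C@H](CO)[C@@H](O)[C@H]2O)c2ncnc(C)c12` has not yet been measured, and it differs from compound 2 in one place: ethynyl in place of furan-3-yl on an aromatic carbon. In words, ethynyl stands in place of furan-3-yl on an aromatic carbon. Compound 1 `C#Cc1cn([C@@H]2O[C@H](CO)[C@@H](O)[C@H]2O)c2ncnc(SC)c12` also carries ethynyl, and in this assay compound 1 gives 110 nM. Among the compounds with values here, no measured pair shows this swap on its own, so the expectation rests on that one value. A large move towards stronger inhibition is expected, estimated as an at least 66-fold lower number from compound 2 to compound 3 (1.82 log units; beyond the scatter). For compound 3 the estimated value is 300 nM, with an expected range from 60 nM to 2000 nM.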

Compound 3, half-maximal inhibitory concentration: 160 nM
Compound 3: middle estimate off by 1.9-fold (0.27 log units), on the high side; low and high end bracket the measured number.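

In this assay, going by these compounds alone, ethynyl in place of furan-3-yl on an aromatic carbon gives an at least 120-fold lower number from compound 2 to compound 3 (2.09 log units; beyond the scatter), the first view of this swap on its own, and it shows that the group at this position can decide between a clear reading and none within the assay's range. Compound 2 reads > 20000 nM, which is a limit of the assay and not a number, so the step has a floor but no known full size: the limit of > 20000 nM in this assay, at which 1 of the 3 values shown sits. With ethynyl kept, methyl in place of methylsulfanyl on an aromatic carbon gives a 1.5-fold higher number from compound 1 to compound 3 (0.16 log units; within the scatter), so these two compounds stand within the scatter of each other.

Open, on these data alone, is how a nitrile, an amine or a longer alkyne chain would read at the ethynyl position, and so whether ethynyl itself matters or simply the absence of furan-3-yl. Also open, as far as these compounds go, is how furan-3-yl reads alongside methylsulfanyl on the shared core.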